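Ester to Ether Exchange in a Cytotoxicity Series

The source may report more compounds than this note shows. Statements on the series, on what has been measured and on what is new or still open speak of the compounds shown alone.

The measured compounds:
compound 1, `CCCC(O)CC(=O)O[C@H](CC=C(C)C)C1=CC(=O)c2c(O)ccc(O)c2C1=O`, which in a functional assay on HeLa cells (Homo sapiens) for cytotoxicity, read by MTT assay (on this read-out higher numbers stand for weaker inhibition and lower numbers for stronger inhibition), gives 59300 nM
compound 2, `CC(C)=CC[C@@H](OC(=O)CCO)C1=CC(=O)c2c(O)ccc(O)c2C1=O`, which in this assay gives 67600 nM
compound 3, `CCCC(C)(O)CC(=O)O[C@H](CC=C(C)C)C1=CC(=O)c2c(O)ccc(O)c2C1=O`, which in this assay gives 72000 nM

Compound 3 holds the highest of the three numbers, yet its nearest neighbour is separated by a 1.1-fold higher number from compound 2 to compound 3 (0.03 log units; within the scatter) and its furthest by a 1.2-fold higher number from compound 1 to compound 3 (0.08 log units; within the scatter), so the three compounds cannot be told apart in this assay. The step of a 1.1-fold higher number from compound 1 to compound 2 (0.06 log units; within the scatter) is likewise within the scatter.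

Compound 4, `CCC(O)CO[C@H](CC=C(C)C)C1=CC(=O)c2c(O)ccc(O)c2C1=O`, differs from compound 3 by 2-hydroxybutyl in place of (2-hydroxy-2-methylpentyl)carbonyl on an oxygen on a saturated carbon. Among the measured compounds shown here, none of the measured steps touches this part of the molecule: each of them alters only the carbon chain attached to the carbonyl, and none moved the number beyond the scatter. They bear on the new change only in showing that the shared core has so far set the read-out regardless of the side chain. The change to compound 4 is larger than any measured one, so the range must be wide, but no direction is indicated. Compound 4 is therefore expected to give 65000 nM, between 30000 nM and 140000 nM, a step of a 1.1-fold lower number from compound 3 to compound 4 (0.04 log units; within the scatter) that is expected to stay within the scatter.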

Compound 4, half-maximal inhibitory concentration: 28700 nM
Beside the measured number, compound 4's estimate is 2.3-fold (0.36 log units) above it; measured number outside the range, below it.
By their numbers in this assay, from the lowest: compound 4; then compounds 1, 2 and 3 (each within the scatter of the next).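

Exchanging the acyl groups on the oxygen on a saturated carbon for 2-hydroxybutyl is the only change shown that moves the number in this assay beyond the scatter, with a 2.5-fold lower number from compound 3 to compound 4 (0.40 log units; beyond the scatter), a 2.4-fold lower number from compound 2 to compound 4 (0.37 log units; beyond the scatter) and a 2.1-fold lower number from compound 1 to compound 4 (0.32 log units; beyond the scatter), all three modest. Varying the chain attached to the carbonyl had left the number within the scatter, whereas this exchange, which removes that carbonyl, shows that the read-out does respond to what sits on this oxygen, and compound 4 is the strongest inhibitor of the four compounds shown. Nothing measured here accounts for this shift.

Compound 4 loses the carbonyl and takes a different chain in a single change, so the compounds shown cannot tell whether the lower number follows the loss of the carbonyl or the 2-hydroxybutyl chain itself. Going by these compounds, it also remains open how this assay would read for a longer chain on this oxygen, or for an amine or a carboxylic acid in place of the hydroxyl on the 2-hydroxybutyl chain.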